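Imidines with benzyl lactam core: hydroxy to methoxy step

The source may hold more compounds than are shown below. What is called first, only, known or untested is meant among the compounds shown, and "the series" means these compounds.

Measured so far:
- compound 1 `COc1ccc(CNC(=N)[C@@H]2CCC(=O)N2Cc2ccccc2)cc1`: 19.5%
- compound 2 `COc1ccc(CNC(=N)[C@@H]2CCC(=O)N2Cc2ccccc2[N+](=O)[O-])cc1`: 25.4%
- compound 3 `N=C(NCc1ccc(O)cc1)[C@@H]1CCC(=O)N1Cc1ccc([N+](=O)[O-])cc1`: 34.5%

In a functional assay on SH-SY5Y cells (Homo sapiens) for cytotoxicity, read by MTT assay, with stated times of 8 h, 30 min and 12 h, tested at 5 uM (a lower number here means a weaker effect, a higher number a stronger effect of the compound at the concentration tested), compound 3 gives the highest of the three numbers. Its gap to compound 2 is within the scatter, so no order between the two can be read. Its gap to compound 1 is beyond the scatter, so compound 3 does stand above compound 1.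

The next compound in the series is compound 4 `COc1ccc(CNC(=N)[C@@H]2CCC(=O)N2Cc2ccc([N+](=O)[O-])cc2)cc1`. It differs from compound 3 in one place: methyl in place of hydrogen on an oxygen on an aromatic ring.

Within the data shown here, only one step between measured compounds is on hand, a number 5.9 percentage points higher from compound 1 to compound 2 (within the scatter). That step concerns a nitro group, not the oxygen of the benzyl substituent, and it is within the scatter. Among the measured compounds shown here, no measured pair tracks a methyl in place of hydrogen on an oxygen on an aromatic ring, so there is no direct guide for the change from compound 3 to compound 4. The two methoxy-bearing compounds, compound 1 and compound 2, both sit below compound 3 in this assay, though only compound 1 does so beyond the scatter.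

For compound 4 the expected step is therefore a number 6.5 percentage points lower from compound 3 to compound 4 (within the scatter), with no confident movement beyond the scatter. Compound 4 is estimated at 28% in this assay, expected between 16% and 40%.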

Compound 4, a percentage reported as activity, at one concentration (the size of the read-out at that concentration, not a potency): 35.2%
Compound 4: the middle estimate sits 7.2 percentage points below what was measured; measured number inside the range.
By their numbers in this assay, from the lowest: compounds 1, 2, 3 and 4 (each within the scatter of the next, the first and the last beyond it).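

In this assay, methyl on the oxygen of the aromatic ring leaves the read-out unresolved (a number 0.7 percentage points higher from compound 3 to compound 4 (within the scatter)), so 4-hydroxybenzyl and 4-methoxybenzyl cannot be told apart at this position on the 4-nitrophenyl background. Compound 4 also gives a second reading of nitro in place of hydrogen: as 4-nitrophenyl, it gives a modest step beyond the scatter (a number 15.7 percentage points higher from compound 1 to compound 4 (beyond the scatter)), whereas the 2-nitrophenyl step stayed within it (a number 5.9 percentage points higher from compound 1 to compound 2 (within the scatter)), yet no order can be read between the two nitro isomers (a number 9.8 percentage points higher from compound 2 to compound 4 (within the scatter)). No measured evidence bearing on these results is available, so nothing can be said about what lies behind them.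

The compounds shown leave open whether the tolerance at this oxygen extends to a longer chain such as ethyl or to an amine in place of the hydroxy group. They also leave open whether hydroxy and methoxy stay indistinguishable with 2-nitrophenyl or with unsubstituted benzyl on the lactam nitrogen, since the only hydroxy compound shown carries 4-nitrophenyl.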